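Swapping hydroxy for fluoro on compound 2

The compounds below may be only part of what the source reports. "The series", "measured", "known", "first", "only" and "open" are said of these compounds alone.

Results so far in a functional assay on T47D cells (Homo sapiens) for inhibition; a lower number here means a stronger inhibitor of growth, a higher number a weaker inhibitor of growth
compound 1 `COc1cc(-c2nncn2-c2ccc(N(C)C)cc2)cc(OC)c1OC` gives 47.9 nM
compound 2 `COc1ccc(-n2cnnc2-c2cc(OC)c(OC)c(OC)c2)cc1O` gives 269 nM

Compound 2 has the higher of the two numbers, so it is the weaker inhibitor of growth, and the gap to compound 1 lies beyond the scatter. Compound 3 `COc1ccc(-n2cnnc2-c2cc(OC)c(OC)c(OC)c2)cc1F` carries fluoro in place of hydroxy on an aromatic carbon. For the measured compounds named here, no measured pair shows this swap, so no direction can be argued, and in this assay no change beyond the scatter is expected. The expected step is small (a 1.1-fold higher number from compound 2 to compound 3 (0.05 log units; within the scatter)). For compound 3 the estimated value is 300 nM (80 nM to 1200 nM).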

Compound 3, concentration for 50% growth inhibition: < 100000 nM
Compound 3: only a limit was reported (the forecaster's own chance of this, stated with the estimate: 5%); the middle value does not contradict the limit.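

For the compounds shown here, compound 3 gave only a limit, not a number, so no step from compound 2 to compound 3 can be read: the limit of < 100000 nM in this assay, at which 1 of the 3 values shown sits.

Left open is how far, if at all, fluoro in place of hydroxy shifts the result in this assay for this pair.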